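The source may hold more compounds than are shown below. What is called first, only, known or untested is meant among the compounds shown, and "the series" means these compounds.

Measured so far in a functional assay on the whole organism (stomach) for inhibition, with Rattus norvegicus as the target, at a dose of 80 mg/kg; a higher number here means more inhibition at the dose given (going by the name of the read-out), a lower number less inhibition:
compound 1 `CC(C)c1ccc(-c2cc(=O)c3cc(C(=O)O)ccc3o2)cc1` — 19%
compound 2 `COc1c(-c2ccc(C(C)C)cc2)oc2ccc(C(=O)O)cc2c1=O` — 18%
compound 3 `Cc1ccc(-c2oc3ccc(C(=O)O)cc3c(=O)c2OC(C)C)cc1` — 8%

Compound 3 stands at the low end of the three numbers. Its gap to compound 1 is beyond the scatter, while compound 2 and compound 3 lie within the scatter of each other, so no order between those two is claimed.

Among the measured compounds shown here, the only single-point step measured, a number 1 percentage points lower from compound 1 to compound 2 (within the scatter), concerns methoxy in place of hydrogen on an aromatic carbon and says nothing about the alkyl group on the outer ring.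

Compound 4 `CC(C)Oc1c(-c2ccc(C(C)C)cc2)oc2ccc(C(=O)O)cc2c1=O` is to be measured in this assay. It differs from compound 3 as follows:
isopropyl in place of methyl on an aromatic carbon
The place is on an aromatic carbon of a six-membered aromatic ring of carbon only, para to a large group. No measured pair isolates this change; compound 1 and compound 2 both carry the isopropyl already, and compound 3 is the only member with methyl at that place, so the step from methyl to isopropyl is unsupported by any shown step. For the measured compounds named here, all three measured values sit low, and the one step measured was within the scatter, so no step beyond the scatter is expected here either.

For compound 4 the expected step is a number 5 percentage points higher from compound 3 to compound 4 (within the scatter). The estimate for compound 4 in this assay is 13%, with a range from 3% to 25%.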

Compound 4, a percentage reported as inhibition, in the whole organism at one dose (the size of the read-out at that dose, not a potency): 20%
Compound 4: the middle estimate sits 7 percentage points below what was measured; the measured number falls inside the stated range.
By their numbers in this assay, from the lowest: compounds 3, 2, 1 and 4 (each within the scatter of the next, the first and the last beyond it).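

In this assay, the step from 4-methylphenyl to 4-isopropylphenyl (a number 12 percentage points higher from compound 3 to compound 4 (beyond the scatter)) is the first in the series beyond the scatter, though it is modest, so the group at this aromatic carbon, para to a large group, is the only single change shown here to move the read-out. With the isopropyl already in place, changes on the oxygen show no such movement: isopropyl in place of methyl on that oxygen gives a step within the scatter (a number 2 percentage points higher from compound 2 to compound 4 (within the scatter)), as does isopropoxy in place of hydrogen on the aromatic carbon (a number 1 percentage points higher from compound 1 to compound 4 (within the scatter)), which extends the earlier methoxy result to a larger group. No measurement here gives a reason for the step from methyl to isopropyl.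

From the compounds shown here alone, the step from methyl to isopropyl is read only with isopropoxy on the oxygen, so whether it holds with methoxy or hydrogen at that place stays open. Going by these compounds, whether a tert-butyl group or a longer chain at this aromatic carbon, or an amine there, would carry the read-out beyond that of compound 4 (20%) also stays open.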